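The source may report more compounds than this note shows. Statements on the series, on what has been measured and on what is new or still open speak of the compounds shown alone.

Measured compounds:
Compound 1 `Clc1ccccc1Cn1nnc2c(NCC3CCCCC3)ncnc21`, 4260 nM.
Compound 2 `Cc1ccc(Nc2ncnc3c2nnn3Cc2ccccc2Cl)cc1`, 119 nM.
Compound 3 `Cc1cccc(Nc2ncnc3c2nnn3Cc2ccccc2Cl)c1`, 5880 nM.

In an assay on cell membranes for binding affinity to adenosine receptor A1 (Bos taurus), read by radioligand binding (on this read-out higher numbers stand for weaker inhibition and lower numbers for stronger inhibition), compound 3 gives the highest number of the three, so it is the weakest binder shown; compound 1 sits within the scatter of it, while compound 2 lies far lower. Compound 4 `Nc1ccc(Nc2ncnc3c2nnn3Cc2ccccc2Cl)cc1` has not yet been measured. It differs from compound 3 by 4-aminophenyl in place of 3-methylphenyl on a nitrogen on an aromatic ring. For the measured compounds named here, two measured steps bear on this change: a 49-fold higher number from compound 2 to compound 3 (1.69 log units; beyond the scatter), and a 36-fold lower number from compound 1 to compound 2 (1.55 log units; beyond the scatter). Both show that a 4-methylphenyl group gives a far lower number than either a 3-methylphenyl or a cyclohexylmethyl group. A 4-aminophenyl group is not the same as 4-methylphenyl, so the gain is uncertain, but a large fall in the number is expected. The step from compound 3 to compound 4 is therefore estimated as a 24-fold lower number from compound 3 to compound 4 (1.37 log units; beyond the scatter), giving compound 4 an expected value of 250 nM (range 50 nM to 1500 nM).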

Compound 4, inhibition constant: > 1000 nM
Compound 4: only a limit was reported (the forecaster's own chance of this, stated with the estimate: 5%); middle value at least 4.0-fold (0.60 log units) away from the limit.
By their numbers in this assay, from the lowest: compound 2; then compounds 1 and 3 (each within the scatter of the next).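

Compound 4 carries a limit and not a number: the limit of > 1000 nM in this assay, at which 1 of the 4 values shown sits. Amino in place of methyl on an aromatic carbon gives an at least 8.4-fold higher number from compound 2 to compound 4 (0.92 log units; beyond the scatter), so the low number seen with 4-methylphenyl does not carry over to 4-aminophenyl, and the group on the ring counts, not only where it sits. The steps to compound 4 from compound 1 and compound 3 cannot be read. Going by these compounds, whether compound 4 lies level with those two stays open. So does how a 4-methoxyphenyl or 4-chlorophenyl group would compare with 4-methylphenyl.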